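The source may report more compounds than this note shows. Statements on the series, on what has been measured and on what is new or still open speak of the compounds shown alone.

Measured in an assay on CHO cells for displacement of a labelled ligand from prostaglandin D2 receptor 2 (Homo sapiens), read by scintillation counting (on this read-out higher numbers stand for weaker inhibition and lower numbers for stronger inhibition), so far:

compound 1 `COCCN(C)S(=O)(=O)c1ccc(C)c(C#Cc2cc(Cl)ccc2OCC(=O)O)c1` — 4.1 nM
compound 2 `Cc1ccc(S(=O)(=O)NC(C)C)cc1C#Cc1cc(Cl)ccc1OCC(=O)O` — 3.4 nM
compound 3 `Cc1ccc(S(=O)(=O)N(C)CCCN(C)C)cc1C#Cc1cc(Cl)ccc1OCC(=O)O` — 287 nM

Compound 3 gives the highest number of the three in this assay; both other compounds lie well apart from it, compound 1 by a 70-fold higher number from compound 1 to compound 3 (1.85 log units; beyond the scatter) and compound 2 by an 84-fold higher number from compound 2 to compound 3 (1.93 log units; beyond the scatter). Compounds 1 and 2, which carry other groups on the sulfonyl sulfur, sit close together, with a 1.2-fold lower number from compound 1 to compound 2 (0.08 log units; within the scatter).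

Compound 4 `Cc1ccc(S(C)(=O)=O)cc1C#Cc1cc(Cl)ccc1OCC(=O)O` has not yet been measured in this assay. It differs from compound 3 in one place: methyl in place of (3-(dimethylamino)propyl)(methyl)amino on a sulfonyl sulfur.

The two steps into compound 3 are what bear on this change. Among the compounds with values here, each of them exchanges a sulfonyl substituent without the (dimethylamino)methyl group for the one in compound 3, and each was large. Within the data shown here, compound 4 removes that group entirely, so a large step in this assay back towards the numbers of compounds 1 and 2 is expected, though no measured compound shows a plain methyl on the sulfonyl sulfur, so the size is uncertain. For compound 4 the expected step is a 48-fold lower number from compound 3 to compound 4 (1.68 log units; beyond the scatter). The estimate for compound 4 in this assay is 6 nM, in the range 1.5 nM to 30 nM.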

Compound 4, inhibition constant: 5 nM
The estimate for compound 4 lay 1.2-fold (0.08 log units) above the measured number; the range from low to high includes it.
By their numbers in this assay, from the lowest: compounds 2, 1 and 4 (each within the scatter of the next); then compound 3.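

In this assay, the plain methyl on the sulfonyl sulfur gives a 57-fold lower number from compound 3 to compound 4 (1.76 log units; beyond the scatter), while a 1.5-fold higher number from compound 2 to compound 4 (0.17 log units; within the scatter) and a 1.2-fold higher number from compound 1 to compound 4 (0.09 log units; within the scatter). A sulfonamide nitrogen at this place is therefore not required for a low number: compounds 1, 2 and 4 cannot be told apart, despite the different groups on the sulfur, and among the four compounds only compound 3, with its (3-(dimethylamino)propyl)(methyl)amino group, stands apart. No supporting data bear on the reason for this result.

The compounds shown leave open whether the high number of compound 3 goes with the terminal dimethylamino group or with the length of its chain. A propyl chain ending in methoxy, or a shorter chain ending in dimethylamino, on the sulfonamide nitrogen would separate these two readings.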